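Exchange of Sulfonamide Groups on the Aryl Terminus

This account rests on a few compounds, and the source may have more. Where it says the series, first, only, none or still open, it means among the compounds named here.

compound 1 `CCCS(=O)(=O)Nc1ccc(F)c(C(=O)c2n[nH]c3ncc(-c4cccc(OC)c4)cc23)c1F`: 6.3%
compound 2 `CCCS(=O)(=O)Nc1ccc(F)c(C(=O)c2n[nH]c3ncc(-c4ccc(S(=O)(=O)NC(C)=O)cc4)cc23)c1F`: 0.35%

In an assay for binding affinity to dual specificity mitogen-activated protein kinase kinase 4 (Homo sapiens), read by KINOMEscan, tested at 100 nM (on this read-out higher numbers stand for a weaker effect at the one concentration tested and lower numbers for a stronger effect), compound 1 gives 6.3% and compound 2 gives 0.35%. Compound 2 stands at the low end of the two numbers, though its gap to compound 1 is within the usual scatter. Compound 3 `CCCS(=O)(=O)Nc1ccc(F)c(C(=O)c2n[nH]c3ncc(-c4ccc(NS(C)(=O)=O)cc4)cc23)c1F` carries methanesulfonamido in place of acetylsulfamoyl on an aromatic carbon. Going by the values given here, no measured pair shows the effect of such a change. Since one sulfonamide gives way to another, the step of a number 0.7 percentage points higher from compound 2 to compound 3 (within the scatter) is expected to stay within the scatter, in no clear direction. Compound 3 is therefore estimated at 1%, with a range from 0.1% to 10%.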

Compound 3, a percentage reported as activity, at one concentration (the size of the read-out at that concentration, not a potency): 0.85%
Estimate against measurement, compound 3: 0.2 percentage points above; the range from low to high includes it.
By their numbers in this assay, from the lowest: compounds 2, 3 and 1 (each within the scatter of the next).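

In this assay, methanesulfonamido on an aromatic carbon para to a large group reads like acetylsulfamoyl there, with a number 0.5 percentage points higher from compound 2 to compound 3 (within the scatter), so the smaller sulfonamide group cannot be told apart from the larger one. Exchanging the whole terminus, 4-(methanesulfonamido)phenyl in place of 3-methoxyphenyl, also gives a number 5.5 percentage points lower from compound 1 to compound 3 (within the scatter). Nothing at hand offers a reason for either result.

Going by these compounds, it remains open whether an amine or a carboxylic acid at this position, or a longer chain in place of the methyl of methanesulfonamido, would read the same. These readings show only the size of the effect at the one concentration tested and leave open how these compounds would read at any other concentration.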